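The source may report more compounds than this note shows. Statements on the series, on what has been measured and on what is new or still open speak of the compounds shown alone.

Measured compounds, with values in a functional assay on A549 cells (Homo sapiens) for antiproliferative activity, read by MTT assay, with a stated time of 72 h; on this read-out lower numbers stand for stronger inhibition and higher numbers for weaker inhibition:
- compound 1 `CCNC(=O)c1cc(Oc2ccc(NC(=O)c3cc4cccnc4n(-c4ccc(F)c(Cl)c4)c3=O)cc2)ccn1`: compound 1 gives 1920 nM
- compound 2 `CCCNC(=O)c1cc(Oc2ccc(NC(=O)c3cc4cccnc4n(-c4ccc(Br)cc4)c3=O)cc2)ccn1`: compound 2 gives 150 nM

Compound 2 holds the lower of the two numbers in this assay; compound 1 stands well above it, a gap beyond the scatter. Within the data shown here, the two differ in two places at once, the amide chain and the aryl group on the ring nitrogen, so no single step between them can be drawn from these numbers.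

Compound 3 `CCCNC(=O)c1cc(Oc2ccc(NC(=O)c3cc4cccnc4n(-c4ccc(F)c(Cl)c4)c3=O)cc2)ccn1` is not yet measured. It keeps the propylamide of compound 2 and carries the aryl group of compound 1: 3-chloro-4-fluorophenyl in place of 4-bromophenyl on an aromatic nitrogen. Among the measured compounds shown here, the data give no isolated step for this swap in this assay; the only guide is that compound 1, with the same aryl group but a shorter amide chain, gives 1920 nM, and compound 2 gives 150 nM. The step from compound 2 to compound 3 is therefore expected to be a loss, moderate but likely beyond the scatter, about a 3.3-fold higher number from compound 2 to compound 3 (0.52 log units; beyond the scatter). Compound 3 is estimated at 500 nM in this assay, within 150 nM to 2000 nM.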

Compound 3, half-maximal inhibitory concentration: 590 nM
Beside the measured number, compound 3's estimate is 1.2-fold (0.07 log units) below it, within the range that was stated.
By their numbers in this assay, from the lowest: compound 2; then compound 3; then compound 1.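

With the propylamide held constant, the aryl group on the aromatic nitrogen can now be read on its own in this assay: 3-chloro-4-fluorophenyl in place of 4-bromophenyl gives a 3.9-fold higher number from compound 2 to compound 3 (0.59 log units; beyond the scatter), so this position responds to the change and 4-bromophenyl is the better of these two groups on this chain. With 3-chloro-4-fluorophenyl held constant, the amide chain can also be read: methyl in place of hydrogen on a saturated chain carbon, two bonds along the chain from an amide-type nitrogen, gives a 3.3-fold lower number from compound 1 to compound 3 (0.51 log units; beyond the scatter), so the gap between compound 1 and compound 2 resolves into one step at each place, each beyond the scatter. No measurement in hand accounts for either step.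

Open, going by these compounds, is whether the aryl swap gives a step of the same size on the shorter amide chain of compound 1, and whether a butyl chain on the amide continues the direction of the methyl step. Also open is where a plain phenyl, a 4-chlorophenyl or a 3-chlorophenyl on the aromatic nitrogen would stand relative to the two aryl groups shown.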